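Extending the Side Chain of a Cationic Cytotoxic Scaffold

This account rests on a few compounds, and the source may have more. Where it says the series, first, only, none or still open, it means among the compounds named here.

Of the compounds shown here, two have been tested in a functional assay on HeLa S3 cells (Homo sapiens) for cytotoxicity, read by MTT assay, with a stated time of 48 h; on this read-out higher numbers stand for weaker inhibition and lower numbers for stronger inhibition. Compound 1 `CCCC/C=C(\C)c1c(C)cc(C)c2[n+]1CCC=C2` gives 680 nM in this assay, while compound 2 `CCCCCC/C=C/c1c(C)cc(C)c2[n+]1CC(C)C=C2` gives 170 nM, the lowest of the two numbers, a gap that lies beyond the usual scatter. Compound 3 `CCCCCCCCCCCC/C=C/c1c(C)cc(C)c2[n+]1CC(C)C=C2` is the next compound, differing from compound 2 by hexyl in place of hydrogen on a saturated chain carbon, six bonds along the chain from a double-bonded chain carbon. Since compound 2 already reaches 170 nM, a modest further drop in this assay is expected, around a 1.7-fold lower number from compound 2 to compound 3 (0.23 log units; within the scatter), possibly no larger than the scatter. Compound 3 is therefore estimated at 100 nM, with a range from 30 nM to 400 nM.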

Compound 3, half-maximal inhibitory concentration: 38 nM
Beside the measured number, compound 3's estimate is 2.6-fold (0.42 log units) above it; measured number inside the range.
By their numbers in this assay, from the lowest: compound 3; then compound 2; then compound 1.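

In this assay, hexyl in place of hydrogen on a saturated chain carbon, six bonds along the chain from a double-bonded chain carbon, gives a 4.5-fold lower number from compound 2 to compound 3 (0.65 log units; beyond the scatter) at this place. The chain of compound 2 could therefore still be lengthened here with a clear gain in strength. Nothing measured explains this gain.

A single step cannot show a trend with chain length. Going by these compounds, it remains open whether a longer chain would lower the number further, or how a chain ending in an amine or a carboxylic acid would behave.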